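A few compounds are considered here, and "the series" means these few. Any claim that something is new, unique, unknown or untested is made for them only; others in the source may bear on it.

Measured so far in an assay on isolated protein for inhibition of Rho-associated protein kinase 2 (Homo sapiens), read by scintillation counting, radiometric assay and 33P incorporation, with a stated time of 40 min, in the presence of a further agent that is not named here; on this read-out lower numbers stand for stronger inhibition and higher numbers for weaker inhibition:
Compound 1 `CN(C)c1ccc(C(=O)Nc2cccc(NC(=O)COc3ccc4c(c3)CCC(=O)N4)c2)cc1` gives 9970 nM.
Compound 2 `COc1cc(OCC(=O)Nc2cccc(NC(=O)c3ccc(N(C)C)cc3)c2)ccc1C=O` gives 306 nM.
Compound 3 `CN(C)c1ccc(C(=O)Nc2cccc(NC(=O)COc3ccc4c(c3)OCCO4)c2)cc1` gives > 10000 nM, which is a limit of the assay and not a number.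

Compound 3 therefore stands at the weak end of these three, and the step of an at least 32-fold higher number from compound 2 to compound 3 (1.51 log units; beyond the scatter) shows how far it lies from compound 2. Compound 4 `CN(C)c1ccc(C(=O)Nc2cccc(NC(=O)COc3ccc4occc(=O)c4c3)c2)cc1` differs from compound 3 in a group of 11 heavy atoms (9 carbon, 2 oxygen; one six-membered aromatic ring of carbon only, one six-membered aromatic ring with 1 hetero atom) in place of a group of 10 heavy atoms (8 carbon, 2 oxygen; one six-membered non-aromatic ring with 2 hetero atoms, one six-membered aromatic ring of carbon only), on an oxygen on a saturated carbon. Among the measured compounds shown here, no measured step changes exactly this group, but a 33-fold lower number from compound 1 to compound 2 (1.51 log units; beyond the scatter) and an at least 32-fold higher number from compound 2 to compound 3 (1.51 log units; beyond the scatter) show that exchanging the group on this oxygen can move this assay strongly in either direction. The entering group, with its two aromatic rings, is expected to give compound 4 a somewhat lower number than the limit of compound 3, as an at least 3.3-fold lower number from compound 3 to compound 4 (0.52 log units; beyond the scatter), with wide uncertainty. Compound 4 is estimated at 3000 nM, between 400 nM and 20000 nM.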

Compound 4, half-maximal inhibitory concentration: > 10000 nM
Compound 4: no number, only a limit; the forecaster's own chance of this, stated with the estimate: 30%; middle value at least 3.3-fold (0.52 log units) away from the limit.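

In this assay compound 4 gives > 10000 nM, which is a limit of the assay and not a number. The step of an at least 32-fold higher number from compound 2 to compound 4 (1.51 log units; beyond the scatter) shows that a group with two aromatic rings on this oxygen does not reach the low number of compound 2. Exchanging the group on this oxygen also gives a number no lower from compound 1 to compound 4 (the limit leaves the size open). The step to compound 4 from compound 3 cannot be read, and a second group on this oxygen now ends at the same limit: the limit of > 10000 nM in this assay, at which 2 of the 4 values shown sit.

On these data alone, it remains open how a group carrying an amine or a carboxylic acid on this oxygen would read, and how far beyond the limit compounds 3 and 4 lie.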